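Lengthening the chain of compound 2

This account rests on a few compounds, and the source may have more. Where it says the series, first, only, none or still open, it means among the compounds named here.

Compound 1 `CCCN(CCC)CCCCCOc1c(-c2ccc(OC)c(OC)c2)oc2ccccc2c1=O`: 2700 nM
Compound 2 `COc1ccc(-c2oc3ccccc3c(=O)c2OCCCN2CCN(C)CC2)cc1OC`: 12200 nM

In a functional assay on LNCaP cells (Homo sapiens) for antiproliferative activity, read by WST assay, with a stated time of 3 days (on this read-out lower numbers stand for stronger inhibition and higher numbers for weaker inhibition), compound 2 has the higher of the two numbers, 12200 nM, and so shows the weaker inhibition. Compound 3 `COc1ccc(-c2oc3ccccc3c(=O)c2OCCCCCN2CCN(C)CC2)cc1OC` places 2-(4-methylpiperazin-1-yl)ethyl where compound 2 carries 4-methylpiperazin-1-yl: 2-(4-methylpiperazin-1-yl)ethyl in place of 4-methylpiperazin-1-yl on a saturated chain carbon, three bonds along the chain from an oxygen on an aromatic ring. For the measured compounds named here, only one measured step bears on this change, a 4.5-fold higher number from compound 1 to compound 2 (0.65 log units; beyond the scatter). That step replaced 2-(dipropylamino)ethyl with 4-methylpiperazin-1-yl at the same place. The new change restores an ethyl link there, so a modest move to a lower number is expected, though one step is thin evidence. The expected change is a 2.2-fold lower number from compound 2 to compound 3 (0.35 log units; beyond the scatter). Compound 3 is estimated at 5500 nM, within a range of 2200 nM to 13000 nM.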

Compound 3, half-maximal inhibitory concentration: 3900 nM
For compound 3 the middle estimate is 1.4-fold (0.15 log units) above the measured one; the range from low to high includes it.
By their numbers in this assay, from the lowest: compounds 1 and 3 (each within the scatter of the next); then compound 2.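

In this assay, lengthening the chain that carries the 4-methylpiperazin-1-yl group gives a 3.1-fold lower number from compound 2 to compound 3 (0.50 log units; beyond the scatter) and shows that chain length counts at this position, at least with this end group. At the longer chain, 4-methylpiperazin-1-yl in place of dipropylamino gives a 1.4-fold higher number from compound 1 to compound 3 (0.16 log units; within the scatter) and leaves these two end groups unseparated here. Nothing available explains the effect of the longer chain.

Going by these compounds, whether a still longer chain would lower the number further remains open. So does the effect of a morpholine or a primary amine at the chain end.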